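A few compounds are considered here, and "the series" means these few. Any claim that something is new, unique, unknown or untested is made for them only; others in the source may bear on it.

Measured compounds:
- Compound 1, `COc1ccc(-c2cc3ccccc3c(-c3ccc(O)cc3)n2)cc1`: 6.7%
- Compound 2, `COc1ccc(-c2cc3cc(C)ccc3c(-c3cccc(O)c3)n2)c(C)c1`: 73.4%
- Compound 3, `COc1cccc(-c2nc(-c3ccc(OC)c(OC)c3)cc3cc(C)ccc23)c1`: 2.9%

These three compounds were tested in an assay on isolated protein for inhibition of DNA topoisomerase 1 (Homo sapiens), with a stated time of 30 min, tested at 100 uM; a higher number here means a stronger effect of the compound at the concentration tested, a lower number a weaker effect. Compound 3 has the lowest of the three numbers, giving 2.9%. Its nearest neighbour is compound 1, whose value of 6.7% lies within the usual scatter of compound 3, so the two cannot be told apart. Compound 2 stands far above both, and its value of 73.4% lies well beyond the scatter of compound 3.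

Compound 4, `COc1ccc(-c2nc(-c3ccc(OC)c(OC)c3)cc3cc(C)ccc23)cc1`, has not yet been measured. It differs from compound 3 in one place: 4-methoxyphenyl in place of 3-methoxyphenyl on an aromatic carbon. Going by the values given here, no directly comparable step between measured compounds is available for this change. Compound 1 also carries a 4-methoxyphenyl group and gives 6.7%, a low number like that of compound 3. On that basis, the step from compound 3 to compound 4 in this assay is expected to be small, with no change beyond the scatter: an estimated a number 3.1 percentage points higher from compound 3 to compound 4 (within the scatter). Compound 4 is therefore expected to give about 6%, in a range from 0% to 25%.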

Compound 4, a percentage reported as inhibition, at one concentration (the size of the read-out at that concentration, not a potency): 2.3%
Estimate against measurement, compound 4: 3.7 percentage points above; measured number inside the range.
By their numbers in this assay, from the lowest: compounds 4, 3 and 1 (each within the scatter of the next); then compound 2.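

Going by these compounds alone, replacing 3-methoxyphenyl with 4-methoxyphenyl on the aromatic carbon next to the ring nitrogen gives a first direct reading of this change in this assay (a number 0.6 percentage points lower from compound 3 to compound 4 (within the scatter)). With everything else in the molecule held the same, moving the methoxy group on this ring therefore leaves the read-out unchanged as far as this assay can tell. The data shown offer no explanation for why the two compounds read alike.

Going by these compounds, it remains open whether a different group on this phenyl ring, such as an amine or a carboxylic acid, would give a different number with the rest of compound 3 unchanged. Within the data shown here, it is also open whether the change from 3-methoxyphenyl to 4-methoxyphenyl would read the same on another core, as this single pair is the only reading of it.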